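Swapping a small ring for a methoxy chain on the core

A few compounds are considered here, and "the series" means these few. Any claim that something is new, unique, unknown or untested is made for them only; others in the source may bear on it.

Three compounds sharing one core were tested in an ADME assay on the whole organism (Macaca fascicularis) for metabolic stability; on this read-out higher numbers stand for a longer-lived compound and lower numbers for a shorter-lived compound. Compound 1 `CCc1sc(N(CC2CC2)[C@H](C)c2ccc(-c3cc(C)ccc3-c3nc(=O)o[nH]3)cc2)nc1C(=O)NS(=O)(=O)C1CC1` gives 3 h. Compound 2 `Cc1ccc(-c2nc(=O)o[nH]2)c(-c2ccc([C@@H](C)N(CC3CC3)c3nc(C(=O)NS(=O)(=O)C4CC4)c(CC(C)C)s3)cc2)c1` gives 2.3 h. Compound 3 `Cc1ccc(-c2nc(=O)o[nH]2)c(-c2ccc([C@@H](C)N(CC3CC3)c3nc(C(=O)NS(=O)(=O)C4CC4)c(C4CC4)s3)cc2)c1` gives 3.1 h, the largest of the three numbers, although the gap to each neighbour is within the usual scatter: a 1.0-fold higher number from compound 1 to compound 3 (0.01 log units; within the scatter) and a 1.3-fold higher number from compound 2 to compound 3 (0.13 log units; within the scatter). The step between the other two is equally small, a 1.3-fold lower number from compound 1 to compound 2 (0.12 log units; within the scatter).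

Compound 4 `COCCc1sc(N(CC2CC2)[C@H](C)c2ccc(-c3cc(C)ccc3-c3nc(=O)o[nH]3)cc2)nc1C(=O)NS(=O)(=O)C1CC1` has not yet been measured. It differs from compound 3 in one place: 2-methoxyethyl in place of cyclopropyl on an aromatic carbon. The two steps that end at compound 3 changed the same position, from ethyl and from isobutyl to cyclopropyl, and neither moved this assay beyond the scatter. With only those two steps to go on, no shift beyond the scatter is expected for the move to 2-methoxyethyl, so a 1.1-fold lower number from compound 3 to compound 4 (0.04 log units; within the scatter) is the expected step. Compound 4 is therefore estimated at 2.8 h, within a range from 1.4 h to 5.6 h.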

Compound 4, half-life: 2.6 h
Estimate against measurement, compound 4: 1.1-fold (0.03 log units) above; the measured number falls inside the stated range.
By their numbers in this assay, from the lowest: compounds 2, 4, 1 and 3 (each within the scatter of the next).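

In this assay the step of a 1.2-fold lower number from compound 3 to compound 4 (0.08 log units; within the scatter) shows that replacing the cyclopropyl ring with 2-methoxyethyl, an open chain that brings an oxygen and a hydrogen-bond acceptor, leaves the number within the scatter. The steps of a 1.1-fold higher number from compound 2 to compound 4 (0.05 log units; within the scatter) and a 1.2-fold lower number from compound 1 to compound 4 (0.06 log units; within the scatter) also stay within the scatter, so in this assay the oxygen-bearing chain cannot be told apart from the all-carbon isobutyl and ethyl groups. Across these four compounds, then, neither a ring, an open carbon chain nor a chain with an oxygen at this position moves the half-life beyond the scatter.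

Nothing measured here explains why the number holds steady at this position. On these data alone, whether an amine, a carboxylic acid or a much longer chain in the same place would shift it beyond the scatter remains open.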